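Thiophen-2-yl for phenyl in two pairs of the series

This account rests on a few compounds, and the source may have more. Where it says the series, first, only, none or still open, it means among the compounds named here.

Compound 1 `NS(=O)(=O)c1ccc(Nc2ncc(/N=C/c3ccccc3)c(NC3CCCC3)n2)cc1` and compound 2 `NS(=O)(=O)c1ccc(Nc2ncc(/N=C/c3cccs3)c(NC3CCCC3)n2)cc1` share one core. In a functional assay on MCF7 cells (Homo sapiens) for antiproliferative activity, read by MTT assay (a higher number here means a weaker inhibitor, a lower number a stronger inhibitor), compound 1 gives 39100 nM and compound 2 gives 23000 nM. Among the measured compounds shown here, the one change between them is thiophen-2-yl in place of phenyl on a carbon with a double bond to nitrogen and the measured step is a 1.7-fold lower number from compound 1 to compound 2 (0.23 log units; within the scatter).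

Compound 3 `CC(C)Nc1nc(Nc2ccc(N3CCN(C)CC3)cc2)ncc1/N=C/c1ccccc1` is built on a different core; the difference between the two cores is not broken down here. In this assay compound 3 reaches only a limit, > 100000 nM, which is the limit of > 100000 nM in this assay, at which 1 of the 3 values shown sits.

Compound 4 `CC(C)Nc1nc(Nc2ccc(N3CCN(C)CC3)cc2)ncc1/N=C/c1cccs1` is not yet measured. It differs from compound 3 by thiophen-2-yl in place of phenyl on a carbon with a double bond to nitrogen, at a place described in the same words as for compound 1 and compound 2, so it is the same change. For the measured compounds named here, the earlier pair gives the only guide: because a 1.7-fold lower number from compound 1 to compound 2 (0.23 log units; within the scatter) lies within the scatter, the step from compound 3 to compound 4 is expected to be small, a step that the limit leaves unreadable from compound 3 to compound 4. Compound 4 is therefore estimated at 120000 nM in this assay, with a range from 50000 nM to 300000 nM, and the result is expected most often to come back as a limit again.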

Compound 4, half-maximal inhibitory concentration: 91100 nM
Estimate against measurement, compound 4: 1.3-fold (0.12 log units) above, and the stated range covers the measured number.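

In this assay, compound 4 gives 91100 nM, and the step on this second core reads as an at least 1.0-fold lower number from compound 3 to compound 4 (0.04 log units; that floor lies within the scatter), so the change yields no step shown to lie beyond the scatter on either core. The value of compound 3 is a limit of the assay and not a number: the limit of > 100000 nM in this assay, at which 1 of the 4 values shown sits. Whether the change carries over with the same size therefore stays unsettled, and a larger step on the second core is not excluded: the same change on two cores in this assay, a 1.7-fold lower number (0.23 log units; within the scatter) from compound 1 to compound 2 and an at least 1.0-fold lower number (0.04 log units; that floor lies within the scatter) from compound 3 to compound 4; the limit leaves it open whether they differ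

The compounds shown hold only phenyl and thiophen-2-yl on a carbon with a double bond to nitrogen, so it remains open whether furan-2-yl, or a phenyl bearing an amine or a carboxylic acid, would give a step beyond the scatter on either core. Compound 1 and compound 3 differ in more than one place, and the compounds shown do not separate how each of those differences contributes to the gap between the two cores.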